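Adding a Methyl to Compound 2

The source may hold more compounds than are shown below. What is called first, only, known or untested is meant among the compounds shown, and "the series" means these compounds.

Compound 1 `N#CN/C(=N\C1CC1)Nc1cccnc1`: 20 mg/kg
Compound 2 `CC(C)(C)N/C(=N\O)Nc1cccnc1`: > 35 mg/kg

In a functional assay on the whole organism (blood, strain Wistar-Okamoto) with Rattus norvegicus as the target, with a stated time of 5 days (on this read-out higher numbers stand for an effect only at larger amounts of compound and lower numbers for an effect already at smaller amounts), compound 1 gives 20 mg/kg. For compound 2 this assay reports only a limit, > 35 mg/kg, not a number. Compound 2 thus sits at the limit of > 35 mg/kg in this assay, at which 1 of the 2 values shown sits, and where it truly stands is open. Compound 3 `CCC(C)(C)N/C(=N\O)Nc1cccnc1` differs from compound 2 by methyl in place of hydrogen on a saturated chain carbon, two bonds along the chain from an amine nitrogen. Going by the values given here, no measured pair shows what this change does here, so the step is expected to be none beyond the scatter, a step that the limit leaves unreadable from compound 2 to compound 3. Compound 3 is therefore estimated at about 45 mg/kg, within a range from 20 mg/kg to 100 mg/kg, and may again return only a limit.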

Compound 3, minimum effective dose: > 20 mg/kg
Compound 3: no number, only a limit (the forecaster's own chance of this, stated with the estimate: 70%); the middle value lies beyond the limit too.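

Going by these compounds alone, compound 2 and compound 3 both return only limits in this assay, and no step between them can be read. Where either compound truly stands, and whether methyl in place of hydrogen changes the minimum effective dose, remains open.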